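Adding a methoxy group to the most active compound

The compounds below may be only part of what the source reports. "The series", "measured", "known", "first", "only" and "open" are said of these compounds alone.

A set of three compounds sharing a closely related core has been tested in a functional assay on HeLa S3 cells (Homo sapiens) for antiproliferative activity, read by MTT assay, with a stated time of 72 h; a higher number here means a weaker inhibitor, a lower number a stronger inhibitor. Compound 1 `COc1cc(N2CCN(C)CC2)ccc1NC1=CC(=O)c2ncccc2C1=O` gives 5260 nM in this assay. Compound 2 `COC(=O)/C=C/c1ccc(CNC2=CC(=O)c3ncccc3C2=O)cc1` gives 5840 nM. Compound 3 `CN1CCN(c2ccc(NC3=CC(=O)c4cccnc4C3=O)cc2)CC1` gives 590 nM, the lowest of the three numbers and therefore the strongest inhibitor of the set, with the other two compounds both clearly weaker by margins well beyond the usual scatter.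

Compound 4 `COc1cc(N2CCN(C)CC2)ccc1NC1=CC(=O)c2cccnc2C1=O` has not yet been measured. It is built from compound 3 by a single change: methoxy in place of hydrogen on an aromatic carbon. Among the compounds with values here, no pair among the measured compounds differs in exactly this one place, so the effect of the change has to be guessed rather than read off. Compound 1 does carry the same methoxy group on the same kind of aniline, yet its core differs from that of compound 3 as well, so its weaker value cannot be laid at the door of the methoxy group alone.

On that basis the expectation for the step from compound 3 to compound 4 is a small loss, a 1.5-fold higher number from compound 3 to compound 4 (0.18 log units; within the scatter), possibly not beyond the scatter. Compound 4 is therefore estimated at 900 nM, with a likely range of 250 nM to 3200 nM.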

Compound 4, half-maximal inhibitory concentration: 4370 nM
Estimate against measurement, compound 4: 4.9-fold (0.69 log units) below; the measured number lies above the stated range.
By their numbers in this assay, from the lowest: compound 3; then compounds 4, 1 and 2 (each within the scatter of the next).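

In this assay, placing a methoxy group on the aromatic carbon ortho to a large group and meta to the 4-methylpiperazin-1-yl group gives a 7.4-fold higher number from compound 3 to compound 4 (0.87 log units; beyond the scatter). Within the data shown here, this is the first direct reading of the change, and it shows that this carbon of the aromatic ring is not indifferent to what it carries: a group of only two heavy atoms, entering in place of a hydrogen atom, is enough to produce a loss well beyond the usual scatter. Nothing available explains why the methoxy group has this effect.

Only hydrogen and methoxy appear at this carbon among the compounds shown, so it remains open whether a fluorine atom, a hydroxyl group or a longer chain such as ethoxy would cost as much, cost less, or cost more. Going by these compounds, it also remains open whether the same step would have a similar size on the core of compound 1, and whether a methoxy group on another carbon of the same aromatic ring would be tolerated better.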